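Chloro in Place of Fluoro: an Expected Dose for Compound 4

The source may report more compounds than this note shows. Statements on the series, on what has been measured and on what is new or still open speak of the compounds shown alone.

Measured compounds:
compound 1, `COc1ccc(-c2cc(-c3ccc(F)cc3)nc(NC(=O)N/N=C\c3cccc(Cl)c3)n2)cc1OC`: 300 mg/kg
compound 2, `C/C(=N/NC(=O)Nc1nc(-c2ccc(C)cc2)cc(-c2ccc(F)cc2)n1)c1ccc([N+](=O)[O-])cc1`: 100 mg/kg
compound 3, `COc1ccc(-c2cc(-c3ccc(Cl)cc3)nc(NC(=O)N/N=C\c3cccc(Cl)c3)n2)cc1OC`: 100 mg/kg

In a functional assay on the whole organism (strain Albino) with Mus musculus as the target, with a stated time of 0.5 h (on this read-out higher numbers stand for an effect only at larger amounts of compound and lower numbers for an effect already at smaller amounts), compound 1 gives 300 mg/kg, and compound 3 gives 100 mg/kg. The two differ only by chloro in place of fluoro on an aromatic carbon, and that change made a 3.0-fold lower number from compound 1 to compound 3 (0.48 log units; beyond the scatter). Compound 2 gives 100 mg/kg, level with compound 3 in this assay; how the core of compound 2 differs from that of compound 1 is not broken down here.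

Compound 4, `C/C(=N/NC(=O)Nc1nc(-c2ccc(C)cc2)cc(-c2ccc(Cl)cc2)n1)c1ccc([N+](=O)[O-])cc1`, is not yet measured. It differs from compound 2 by chloro in place of fluoro on an aromatic carbon, the same change as from compound 1 to compound 3. Because compound 1 to compound 3 showed a 3.0-fold lower number from compound 1 to compound 3 (0.48 log units; beyond the scatter), a similar step is expected here, and compound 4 is estimated to show a 2.0-fold lower number from compound 2 to compound 4 (0.30 log units; within the scatter). Compound 4 is therefore expected to give about 50 mg/kg, most likely between 25 mg/kg and 120 mg/kg.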

Compound 4, dose for half-maximal effect: 100 mg/kg
Compound 4: the middle estimate sits 2.0-fold (0.30 log units) below what was measured; low and high end bracket the measured number.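

In this assay, replacing 4-fluorophenyl with 4-chlorophenyl gave no change at the digits printed from compound 2 to compound 4 (within the scatter). The step seen on the core of compound 1 therefore did not carry over in size to the core of compound 2: the same change on two cores in this assay, a 3.0-fold lower number (0.48 log units; beyond the scatter) from compound 1 to compound 3 and no change at the digits printed (within the scatter) from compound 2 to compound 4, 3.0-fold (0.48 log units) apart, beyond the scatter of two such steps This shows that, for these two pairs, the result of the change cannot simply be transferred from one core to the other, but it does not show which difference between the cores goes with the gap, or what the change would do on any further core.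

The compounds shown leave open how a bromo group or an amine in place of the chloro would read out on either core. They also leave open whether a third core would follow compound 1 to compound 3 or compound 2 to compound 4.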